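Bromo to nitro on the aryl sulfonate series

The source may report more compounds than this note shows. Statements on the series, on what has been measured and on what is new or still open speak of the compounds shown alone.

Measured so far in a functional assay on MCF7 cells (Homo sapiens) for antiproliferative activity, read by sulforhodamine B assay, with a stated time of 48 h; on this read-out lower numbers stand for stronger inhibition and higher numbers for weaker inhibition:
- compound 1 `Cc1cccc(OS(=O)(=O)c2ccc(N3CCN(C)C3=O)cc2)c1`: 5100 nM
- compound 2 `CN1CCN(c2ccc(S(=O)(=O)Oc3cccc(F)c3)cc2)C1=O`: > 100000 nM
- compound 3 `CN1CCN(c2ccc(S(=O)(=O)Oc3cccc(Br)c3)cc2)C1=O`: 1500 nM

Compound 2 at > 100000 nM is a limit of the assay, not a number.

Among the measured compounds shown here, compound 3 at 1500 nM holds the lowest number so far in this assay. Against the methyl compound, the bromo swap gives a 3.4-fold lower number from compound 1 to compound 3 (0.53 log units; beyond the scatter), a modest step. Against the fluoro compound, it gives an at least 66-fold lower number from compound 2 to compound 3 (1.82 log units; beyond the scatter), a large step that rests on a limit.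

The next change sits on an aromatic carbon, meta to a large group: compound 4 `CN1CCN(c2ccc(S(=O)(=O)Oc3cccc([N+](=O)[O-])c3)cc2)C1=O` carries nitro in place of bromo (nitro in place of bromo on an aromatic carbon).

All three measured steps are swaps at this one carbon, and the third is an at least 19-fold higher number from compound 1 to compound 2 (1.29 log units; beyond the scatter). They show that the read-out responds strongly to the group placed here, but none of them involves nitro. With compound 3 at the low end at 1500 nM, a move to a higher number is expected, probably modest in size, though a large one cannot be excluded.

The expected change is a 3.0-fold higher number from compound 3 to compound 4 (0.48 log units; beyond the scatter). Compound 4 is estimated at 4500 nM, with an expected range of 800 nM to 30000 nM.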

Compound 4, half-maximal inhibitory concentration: > 100000 nM
Compound 4 was reported as a limit; the forecaster's own chance of this, stated with the estimate: 15%; middle value at least 22-fold (1.34 log units) away from the limit.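

In this assay the four groups at this aromatic carbon now fall into two sets, with methyl and bromo giving readable numbers while fluoro and nitro share a single ceiling: the limit of > 100000 nM in this assay, at which 2 of the 4 values shown sit.

Nitro therefore joins fluoro on the far side of that split, with an at least 66-fold higher number from compound 3 to compound 4 (1.82 log units; beyond the scatter) against bromo and an at least 19-fold higher number from compound 1 to compound 4 (1.29 log units; beyond the scatter) against methyl, so a readable number at this carbon is confined to two of the four groups shown. The value of compound 4 is a limit of the assay and not a number, and the step that joins it to compound 2 cannot be read, which leaves nitro and fluoro without any order between them.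

Open is whether this split holds beyond the four groups shown, which chloro, a nitrile or an amine at the same carbon would test. Also open, on these data alone, is how far past the ceiling compound 2 and compound 4 lie, and whether bromo at another carbon of the same ring keeps a readable number in this assay.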